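The source may report more compounds than this note shows. Statements on the series, on what has been measured and on what is new or still open speak of the compounds shown alone.

Measured in a functional assay on KB cells (Homo sapiens) for antiproliferative activity, read by sulforhodamine B assay, with a stated time of 3 days; on this read-out lower numbers stand for an effect already at smaller amounts and higher numbers for an effect only at larger amounts of compound:

Compound 1 `CCC1=C(O)c2c(oc(-c3ccc(CC(C)C)cc3)cc2=O)C(CC)(CC)C1=O`: 29.3 uM
Compound 2 `CCC1=C(O)c2c(oc(-c3ccc(SC)cc3)cc2=O)C(CC)(CC)C1=O`: > 52.1 uM
Compound 3 `CCC1=C(O)c2c(oc(-c3cccc(C(F)(F)F)c3)cc2=O)C(CC)(CC)C1=O`: 35.7 uM

Compound 2 stands at the limit of > 52.1 uM in this assay, at which 1 of the 3 values shown sits, a limit of the assay rather than a number; compounds 1 and 3 give numbers, and those two sit within the scatter of one another. Going by the values given here, the one step touching the same site, an at least 1.7-fold higher number from compound 1 to compound 2 (0.24 log units; that floor lies within the scatter), runs to the limit, so its true size is open.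

Compound 4 `CCC1=C(O)c2c(oc(-c3ccc(C)c(Cl)c3)cc2=O)C(CC)(CC)C1=O` differs from compound 2 by 3-chloro-4-methylphenyl in place of 4-(methylsulfanyl)phenyl on an aromatic carbon. Every aryl variant shown sits in the same weak region, so no large move is expected either way. Compound 4 is estimated to land where compounds 1 and 3 lie, which against the floor of compound 2 means a step of an at least 1.4-fold lower number from compound 2 to compound 4 (0.17 log units; that floor lies within the scatter), toward a lower number but not beyond the scatter of that floor. The estimate for compound 4 is 35 uM, with a range from 15 uM to 80 uM, and a fair chance that only a limit is returned.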

Compound 4, concentration for half-maximal effect: 39 uM
Compound 4: middle estimate off by 1.1-fold (0.05 log units), on the low side; the range from low to high includes it.
By their numbers in this assay, from the lowest: compounds 1, 3 and 4 (each within the scatter of the next). At a limit, above all of these: compound 2.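

In this assay, 3-chloro-4-methylphenyl on this aromatic carbon next to the ring oxygen returns a number, and compound 4 joins compounds 1 and 3 in a single band, each within the scatter of the next. This position therefore now holds three differently substituted aryl groups that the assay does not tell apart. Against 4-(methylsulfanyl)phenyl the change reads as an at least 1.3-fold lower number from compound 2 to compound 4 (0.12 log units; that floor lies within the scatter), and its true size stays open, as compound 2 gives a limit and not a number: the limit of > 52.1 uM in this assay, at which 1 of the 4 values shown sits.

Open, from the compounds shown here alone, is how far compound 2 really lies from this band, and whether the methylsulfanyl group sets it apart at all. Also open, going by these compounds, is whether an amine or a carboxylic acid on the aryl ring would move the number out of the band.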